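The source may report more compounds than this note shows. Statements on the series, on what has been measured and on what is new or still open speak of the compounds shown alone.

Within the data shown here, compound 2 `CN1CCN(C(=O)c2c(N)sc(-c3ccc(Cl)cc3)c2-c2ccc(Cl)cc2)CC1` is one of two compounds measured so far in a functional assay on A549 cells (Homo sapiens) for inhibition, read by sulforhodamine B assay, with a stated time of 72 h; a higher number here means a weaker inhibitor, a lower number a stronger inhibitor; compound 2 gives 590 nM, the lower of the two numbers. Among the measured compounds shown here, its only neighbour is compound 1 `Nc1sc(-c2ccc(Cl)cc2)c(-c2ccc(Cl)cc2)c1C(=O)Nc1ccccc1`, which in this assay gives 25000 nM. The two differ solely at the carbonyl carbon, and the step of a 42-fold lower number from compound 1 to compound 2 (1.63 log units; beyond the scatter) shows that the group on that carbon can move the number a long way. Compound 3 `COC(=O)c1c(N)sc(-c2ccc(Cl)cc2)c1-c1ccc(Cl)cc1` is not yet measured; it differs from compound 2 as follows: methoxy in place of 4-methylpiperazin-1-yl on a carbonyl carbon. For the measured compounds named here, the single step from compound 1 to compound 2 is the only one that bears on this change, as it alters the same carbonyl carbon, and that step was large. The methoxy group matches neither of the two groups already tried, so the new number could land anywhere between them. The expectation is that compound 3 comes out with a higher number than compound 2, a step of roughly an 8.5-fold higher number from compound 2 to compound 3 (0.93 log units; beyond the scatter). Compound 3 is therefore estimated at 5000 nM, with a range from 1000 nM to 25000 nM.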

Compound 3, half-maximal inhibitory concentration: 5040 nM
Estimate against measurement, compound 3: 1.0-fold (0.00 log units) below; the measured number falls inside the stated range.
By their numbers in this assay, from the lowest: compound 2; then compound 3; then compound 1.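

With methoxy on the carbonyl carbon, the series in this assay now has a middle point, and both steps to it are beyond the scatter: replacing 4-methylpiperazin-1-yl gives a clear rise (an 8.5-fold higher number from compound 2 to compound 3 (0.93 log units; beyond the scatter)), while replacing anilino gives a clear fall (a 5.0-fold lower number from compound 1 to compound 3 (0.70 log units; beyond the scatter)). So the number does not simply follow whether a ring is present on this carbon, since the two ring-bearing groups, anilino and 4-methylpiperazin-1-yl, land on opposite sides of the ring-free methoxy, and a small group is enough to give a lower number than anilino does. No measurement shown here accounts for this order of the three groups.

What the compounds shown leave open is which part of the 4-methylpiperazin-1-yl group goes with its low number, a question that piperazin-1-yl without the methyl, morpholin-4-yl or a simple open-chain amine such as dimethylamino on the same carbonyl carbon could address. They also leave open how a carboxylic acid or a longer ester chain such as ethoxy would rank against these three groups.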